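Swapping Fluoro for Methyl on the Outer Ring

This account rests on a few compounds, and the source may have more. Where it says the series, first, only, none or still open, it means among the compounds named here.

Of the compounds shown here, three sharing one core have been measured in an assay on THP-1 cells for displacement of a labelled ligand from C-C chemokine receptor type 1 (Homo sapiens); on this read-out lower numbers stand for stronger inhibition and higher numbers for weaker inhibition. Compound 1 `CC[C@@H](NC(=O)CC(C)C)C(=O)N1CCC(c2ccc(Cl)cc2)CC1` gives 152 nM. Compound 2 `CC(C)C(NC(=O)c1ccccc1)C(=O)N1CCC(c2ccc(F)cc2)CC1` gives 423 nM. Compound 3 `CC(C)[C@@H](NC(=O)CCc1ccc(F)cc1)C(=O)N1CCC(c2ccc(Cl)cc2)CC1` gives 70 nM, the lowest of the three numbers; its distance to compound 1 and to compound 2 lies beyond the usual scatter of repeated measurements, so compound 3 stands as the strongest binder of the three.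

Compound 4 `Cc1ccc(CCC(=O)N[C@@H](C(=O)N2CCC(c3ccc(Cl)cc3)CC2)C(C)C)cc1` has not yet been measured. It differs from compound 3 in a single place: methyl in place of fluoro on an aromatic carbon. Among the compounds with values here, no pair of measured compounds shows this same change, so its effect cannot be read from the numbers at hand; the rest of the molecule, including the core and the side chain that carries the ring, is unchanged. With a change of one heavy atom for one heavy atom at the far end of the side chain, the expectation is a step of a 1.1-fold higher number from compound 3 to compound 4 (0.06 log units; within the scatter), which is to say no movement beyond the scatter. Compound 4 is therefore expected to give 80 nM in this assay, with a range from 30 nM to 200 nM.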

Compound 4, half-maximal inhibitory concentration: 105 nM
Compound 4: the middle estimate sits 1.3-fold (0.12 log units) below what was measured, and the stated range covers the measured number.
By their numbers in this assay, from the lowest: compounds 3, 4 and 1 (each within the scatter of the next, the first and the last beyond it); then compound 2.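

Within the data shown here, compound 3 and compound 4 are the first pair in this set that differ in one place only, which gives the first direct reading of what happens at the far end of the side chain. In this assay the exchange of fluoro for methyl, on an aromatic carbon para to a large group, gives a 1.5-fold higher number from compound 3 to compound 4 (0.18 log units; within the scatter) and so the two groups cannot be told apart at this position, even though a fluorine atom and a methyl carbon are different kinds of substituent. Nothing available here offers an explanation of why these two groups read alike.

On these data alone, what a methoxy group, an amine or a carboxylic acid would do at the same place stays open, since two groups that read alike do not show how much variation this position accepts. Also open, as far as these compounds go, is whether fluoro and methyl would read alike on a different side chain or with a different group on the shared core, as this exchange appears here in a single pair.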